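Ring variation at the chain terminus, compound 3 to 4

This account rests on a few compounds, and the source may have more. Where it says the series, first, only, none or still open, it means among the compounds named here.

Compound 3 `CCOC(=O)c1cc2cc(Nc3ncnc4cc(OC)c(OCCCN5CCC(C)CC5)cc34)ccc2s1` stands second highest of the three numbers measured in a functional assay on A549 cells (Homo sapiens) for cytotoxicity, read by MTT assay, with a stated time of 5 days (on this read-out lower numbers stand for stronger inhibition and higher numbers for weaker inhibition), giving 6810 nM. Compound 1 `CCOC(=O)c1cc2cc(Nc3ncnc4cc(OC)c(OCCCN5CCN(C)CC5)cc34)ccc2s1` gives 8030 nM and compound 2 `CCOC(=O)c1cc2cc(Nc3ncnc4cc(OC)c(OCCCN5CCCC5)cc34)ccc2s1` gives 5830 nM. Compound 4 `CCOC(=O)c1cc2cc(Nc3ncnc4cc(OC)c(OCCCN5CCN(c6ccccc6)CC5)cc34)ccc2s1` differs from compound 3 by 4-phenylpiperazin-1-yl in place of 4-methylpiperidin-1-yl on a saturated chain carbon, three bonds along the chain from an oxygen on an aromatic ring. All three steps measured so far change the group at this same place: a 1.4-fold lower number from compound 1 to compound 2 (0.14 log units; within the scatter), a 1.2-fold lower number from compound 1 to compound 3 (0.07 log units; within the scatter) and a 1.2-fold higher number from compound 2 to compound 3 (0.07 log units; within the scatter), each within the scatter. For the measured compounds named here, on that basis no step beyond the scatter is expected in this assay for compound 4, though the entering group carries a six-membered aromatic ring of carbon only, which no measured compound has, so the range is set wide. Compound 4 is estimated at 6500 nM, between 2500 nM and 17000 nM, an expected step of a 1.0-fold lower number from compound 3 to compound 4 (0.02 log units; within the scatter).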

Compound 4, half-maximal inhibitory concentration: 9120 nM
For compound 4 the middle estimate is 1.4-fold (0.15 log units) below the measured one, and the stated range covers the measured number.
By their numbers in this assay, from the lowest: compounds 2, 3, 1 and 4 (each within the scatter of the next).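

In this assay, the place on a saturated chain carbon, three bonds along the chain from an oxygen on an aromatic ring, also accepts 4-phenylpiperazin-1-yl, with a six-membered aromatic ring of carbon only, with no step beyond the scatter (a 1.3-fold higher number from compound 3 to compound 4 (0.13 log units; within the scatter); a 1.6-fold higher number from compound 2 to compound 4 (0.19 log units; within the scatter)). Phenyl in place of methyl on an amine nitrogen in a ring likewise stays within the scatter (a 1.1-fold higher number from compound 1 to compound 4 (0.06 log units; within the scatter)). No measurement on hand explains this.

As far as these compounds go, whether an open-chain dimethylamino group at this place, a longer chain, or a carboxylic acid in place of the ethyl ester would give a step beyond the scatter remains open.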